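Nitro in Place of Methylsulfanyl: An Expected Shift in Potency

This account rests on a few compounds, and the source may have more. Where it says the series, first, only, none or still open, it means among the compounds named here.

Measured compounds:
compound 1, `COc1cc(C(=O)/C=C/c2cn(C)c3ccccc23)cc(SC)c1OC`: 150 nM
compound 2, `COc1cc(C(=O)/C(C)=C/c2c[nH]c3ccccc23)cc([Se]C)c1OC`: 18 nM
compound 3, `COc1ccc2c(/C=C/C(=O)c3cc(N)c(OC)c(OC)c3)c[nH]c2c1`: 186 nM

All three were tested in a functional assay on MHCC97H cells (Homo sapiens) for antiproliferative activity, read by MTT assay, with a stated time of 48 h; a higher number here means a weaker inhibitor, a lower number a stronger inhibitor. Compound 1 gives 150 nM, the second highest of the three numbers. Its closest neighbour is compound 3, whose value of 186 nM lies within the usual scatter, so the two cannot be ordered. Compound 2, with 18 nM, sits well below compound 1, a gap beyond the scatter.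

The unmeasured compound 4, `COc1cc(C(=O)/C=C/c2cn(C)c3ccccc23)cc([N+](=O)[O-])c1OC`, is compound 1 with one change: nitro in place of methylsulfanyl on an aromatic carbon. Among the measured compounds shown here, no pair of measured compounds differs in just this way, so there is no directly comparable step to lean on. A nitro group brings a different shape and count of acceptors than methylsulfanyl, and without a precedent the expectation is a modest weakening, only slightly beyond the scatter, as the step of a 2.1-fold higher number from compound 1 to compound 4 (0.33 log units; beyond the scatter) in this assay. Compound 4 is therefore estimated at 320 nM in this assay, with a range from 110 nM to 950 nM.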

Compound 4, half-maximal inhibitory concentration: 850 nM
The estimate for compound 4 lay 2.7-fold (0.42 log units) below the measured number; the range from low to high includes it.
By their numbers in this assay, from the lowest: compound 2; then compounds 1 and 3 (each within the scatter of the next); then compound 4.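

In this assay, the change of methylsulfanyl to nitro on this aromatic carbon, ortho to a methoxy group, gives a 5.7-fold higher number from compound 1 to compound 4 (0.75 log units; beyond the scatter), a clear weakening. The earlier compounds differ from one another in more than one place, so this is the first step shown that isolates a single change, and it shows that the group at this position matters for the antiproliferative reading. Nothing in the data shown accounts for the size of this loss.

Among the compounds shown here, only one pair speaks to this position, so it remains open how a nitrile or a carboxylic acid would fare there on the core of compound 1. From the compounds shown here alone, it is also open whether the same exchange would cost as much on a different core, or in other cell lines.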